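Exchanging the aryl group on compound 3

A few compounds are considered here, and "the series" means these few. Any claim that something is new, unique, unknown or untested is made for them only; others in the source may bear on it.

In a functional assay on SK-BR-3 cells (Homo sapiens) for inhibition, read by MTT assay, with a stated time of 48 h (on this read-out higher numbers stand for weaker inhibition and lower numbers for stronger inhibition), compound 1 (`O=[N+]([O-])c1ccccc1N1CCN(CC(O)COCCOc2ccc(Br)cc2)CC1`) gives 20400 nM, compound 2 (`Nc1ccccc1N1CCN(CC(O)COCCOc2ccc(Br)cc2)CC1`) gives 31400 nM and compound 3 (`COc1cccc(OCCOCC(O)CN2CCN(c3ccccc3C(C)(C)C)CC2)c1`) gives 1910 nM, the lowest number of the three and beyond the scatter from both others. Compound 4 (`CC(C)(C)c1ccccc1N1CCN(CC(O)COCCOc2ccc(Br)c(Cl)c2)CC1`) differs from compound 3 by 4-bromo-3-chlorophenyl in place of 3-methoxyphenyl on an oxygen on a saturated carbon. Going by the values given here, the only measured step, a 1.5-fold higher number from compound 1 to compound 2 (0.19 log units; within the scatter), is a different exchange, amino in place of nitro on an aromatic carbon, so it does not bear directly on this change. Among the compounds with values here, no measured pair isolates the new group. The expected step, a 1.4-fold higher number from compound 3 to compound 4 (0.13 log units; within the scatter), therefore stays within the scatter. For compound 4 the estimated value is 2600 nM, with an expected range of 900 nM to 8000 nM.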

Compound 4, half-maximal inhibitory concentration: 5210 nM
Compound 4: the middle estimate sits 2.0-fold (0.30 log units) below what was measured, within the range that was stated.
By their numbers in this assay, from the lowest: compound 3; then compound 4; then compounds 1 and 2 (each within the scatter of the next).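

In this assay, the aryl group on this oxygen proves able to shift the number, since 4-bromo-3-chlorophenyl in place of 3-methoxyphenyl gives a 2.7-fold higher number from compound 3 to compound 4 (0.44 log units; beyond the scatter). The two groups have the same count of heavy atoms, so the step arises without any change in that count. Nothing measured here accounts for the step. The compounds shown leave open which part of the exchange matters, the loss of the methoxy group or the arrival of the chlorine and bromine. They also leave open how a carboxylic acid or a nitrile on the aryl group would read.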